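A few compounds are considered here, and "the series" means these few. Any claim that something is new, unique, unknown or untested is made for them only; others in the source may bear on it.

Compound 1 `NS(=O)(=O)c1ccccc1-n1nc(C(F)(F)F)c2c1C(=O)N(c1ccc(-c3ccccc3CN3CC[C@@H](O)C3)cc1)CC2`: 645 nM
Compound 2 `CN(C)Cc1ccccc1-c1ccc(N2CCc3c(C(F)(F)F)nn(-c4cccc(C(N)=O)c4)c3C2=O)cc1`: 500 nM

In a functional assay on the whole organism for inhibition, with Oryctolagus cuniculus as the target (on this read-out higher numbers stand for weaker inhibition and lower numbers for stronger inhibition), compound 2 gives 500 nM, which lies within the usual scatter of compound 1, so these two cannot be told apart. Compound 3 `NC(=O)c1cccc(-n2nc(C(F)(F)F)c3c2C(=O)N(c2ccc(-c4ccccc4CN4CC[C@@H](O)C4)cc2)CC3)c1` differs from compound 2 in one place: 3-hydroxypyrrolidin-1-yl in place of dimethylamino on a saturated chain carbon bound to an aromatic carbon. In words, 3-hydroxypyrrolidin-1-yl stands in place of dimethylamino on a saturated chain carbon bound to an aromatic carbon. Compound 1 also carries 3-hydroxypyrrolidin-1-yl and gives 645 nM, so no change beyond the scatter is expected in this assay, in either direction. The expected step is a 1.1-fold higher number from compound 2 to compound 3 (0.04 log units; within the scatter). For compound 3 the estimated value is 550 nM, with an expected range of 220 nM to 1400 nM.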

Compound 3, half-maximal inhibitory concentration: > 780 nM
Compound 3 was reported as a limit; the forecaster's own chance of this, stated with the estimate: 3%; middle value at least 1.4-fold (0.15 log units) from the limit.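

In this assay compound 3 is reported only as a limit, > 780 nM. Going by these compounds alone, these are the first pairs here that isolate single changes: 3-hydroxypyrrolidin-1-yl replacing dimethylamino gives an at least 1.5-fold higher number from compound 2 to compound 3 (0.19 log units; that floor lies within the scatter), and 3-carbamoylphenyl replacing 2-sulfamoylphenyl on an aromatic nitrogen gives an at least 1.2-fold higher number from compound 1 to compound 3 (0.08 log units; that floor lies within the scatter). Neither change can be given a true size, so the result shows only a floor for each: the limit of > 780 nM in this assay, at which 1 of the 3 values shown sits.

From the compounds shown here alone, how far compound 3 really lies from the other two stays open. So does the effect of another amine, such as morpholin-4-yl or piperidin-1-yl, on a saturated chain carbon bound to an aromatic carbon.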